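The compounds below may be only part of what the source reports. "The series", "measured", "known", "first", "only" and "open" are said of these compounds alone.

Compound 1 `CC1(C)CC2CC(C)(CN2C(=O)c2sc(-c3ccc(S(C)(=O)=O)c([N+](=O)[O-])c3)nc2C(F)(F)F)C1` belongs to a small set of amides built on a shared core and examined in a functional assay on HepG2 cells (Homo sapiens) for cytotoxicity, read by luminescence, with a stated time of 72 h; on this read-out higher numbers stand for an effect only at larger amounts of compound and lower numbers for an effect already at smaller amounts. In this assay compound 1 gives only a limit, > 27000 nM. Compound 2 `CN(Cc1cccc(F)c1)C(=O)c1cnc(-c2ccc(S(C)(=O)=O)c([N+](=O)[O-])c2)s1` also gives only a limit in this assay, > 27000 nM. Compound 3 `Cc1nc(-c2ccc(S(C)(=O)=O)c([N+](=O)[O-])c2)sc1C(=O)N1CC2(C)CC1CC(C)(C)C2` too gives only a limit in this assay, > 27000 nM. Among the compounds with values here, the one single-point step, a step that the two limits leave unreadable from compound 1 to compound 3, cannot be sized, since (the limit of > 27000 nM in this assay, at which 3 of the 3 values shown sit). Compound 4 `CS(=O)(=O)c1ccc(-c2nc(C(F)(F)F)c(C(=O)N3CCCCC3)s2)cc1[N+](=O)[O-]` differs from compound 1 by a group of 6 heavy atoms (5 carbon, 1 nitrogen; one six-membered non-aromatic ring with 1 hetero atom) in place of a group of 11 heavy atoms (10 carbon, 1 nitrogen; one five-membered non-aromatic ring with 1 hetero atom, one six-membered non-aromatic ring of carbon only), on a carbonyl carbon. Within the data shown here, no measured step bears on this change, and every value so far stands at the limit. Compound 4 is therefore expected to sit at that limit as well, estimated at 30000 nM with a range from 15000 nM to 60000 nM, because compound 1 gives > 27000 nM. This estimate means an expected step that the limit leaves unreadable from compound 1 to compound 4.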

Compound 4, half-maximal effective concentration: > 27000 nM
Compound 4: no number, only a limit; the forecaster's own chance of this, stated with the estimate: 80%; the middle value is on the limit's open side.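

No step can be read between compound 1 and compound 4, since both give only a limit: the limit of > 27000 nM in this assay, at which 4 of the 4 values shown sit. The compounds shown leave open whether piperidin-1-yl and the larger group it replaces differ at all in cytotoxicity.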